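Methylsulfanyl Added to an Inactive Fused Nucleoside

The source may hold more compounds than are shown below. What is called first, only, known or untested is meant among the compounds shown, and "the series" means these compounds.

Compound 1 `Cc1nsc2c1ncn2[C@H]1C[C@H](O)[C@@H](CO)O1` and compound 3 `Cc1nsc2ncn([C@H]3C[C@H](O)[C@@H](CO)O3)c12` are built from the same atoms joined differently; the difference between the two cores is not broken down here. In a functional assay on KB cells (Homo sapiens) for antiproliferative activity (on this read-out higher numbers stand for weaker inhibition and lower numbers for stronger inhibition), compound 1 gives only a limit of the assay, > 100000 nM. Compound 3 in this assay also gives only a limit, > 100000 nM. Compound 2 `CSc1nc2c(C)nsc2n1[C@H]1C[C@H](O)[C@@H](CO)O1` differs from compound 1 by methylsulfanyl in place of hydrogen on an aromatic carbon. In this assay compound 2 gives only a limit as well, > 100000 nM. The size of the step that the two limits leave unreadable from compound 1 to compound 2 cannot be read, because of the limit of > 100000 nM in this assay, at which 3 of the 3 values shown sit.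

Compound 4 `CSc1nc2snc(C)c2n1[C@H]1C[C@H](O)[C@@H](CO)O1` has not yet been measured in this assay. It differs from compound 3 by methylsulfanyl in place of hydrogen on an aromatic carbon, the same change that separates compound 2 from compound 1, with the same surroundings. Since compound 3 sits at the limit > 100000 nM and the earlier step that the two limits leave unreadable from compound 1 to compound 2 ended at a limit, the step from compound 3 to compound 4 is expected to be a step that the limit leaves unreadable from compound 3 to compound 4, most likely leaving compound 4 beyond measurement. Compound 4 is therefore estimated at 150000 nM, between 50000 nM and 500000 nM.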

Compound 4, half-maximal inhibitory concentration: 30000 nM
Compound 4: middle estimate off by 5.0-fold (0.70 log units), on the high side; measured number outside the range, below it.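

In this assay, putting methylsulfanyl in place of hydrogen on an aromatic carbon of the core of compound 3 gives an at least 3.3-fold lower number from compound 3 to compound 4 (0.52 log units; beyond the scatter), so on this core the change turns a compound without a readable value into one with a measured value. The same change on the core of compound 1 cannot be sized, because compound 1 and compound 2 both stop at the assay's limit: the limit of > 100000 nM in this assay, at which 3 of the 4 values shown sit. Carrying the change from one core to the other is therefore neither confirmed nor ruled out, and this single readable pair says nothing about why the change acts as it does.

From the compounds shown here alone, the true size of the step also stays open, since compound 3 has only a limit and the real distance could be larger than the printed one. The compounds shown also leave open whether an amine or a longer chain such as ethylsulfanyl on the same aromatic carbon would give a lower number on either core.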